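The source may hold more compounds than are shown below. What is called first, only, known or untested is meant among the compounds shown, and "the series" means these compounds.

Measured compounds:
compound 1, `O=C(/C=C/c1ccccc1)NNC(=O)c1ccccc1O` — in a functional assay on PC-3 cells (Homo sapiens) for cytotoxicity, read by MTT assay, with a stated time of 72 h (a higher number here means a weaker inhibitor, a lower number a stronger inhibitor), compound 1 gives 40900 nM
compound 2, `COCOc1cc(/C=C/C(=O)OCC(=O)Nc2ccc(OC)cc2)ccc1OCc1ccccc1` — in this assay compound 2 gives only > 200000 nM, a limit of the assay

Compound 1 is the only one of the two with a number. As far as these compounds go, compound 2 stands at the limit of this assay, the line at which one of the two values sits (the limit of > 200000 nM in this assay, at which 1 of the 2 values shown sits); where it lies beyond that line is unknown. Compound 3, `COCOc1cc(/C=C/C(=O)OCC(=O)Nc2ccc(Cl)cc2)ccc1OCc1ccccc1`, keeps everything of compound 2 except chloro in place of methoxy on an aromatic carbon, para to a large group, on the (4-methoxyphenyl)carbamoyl end, which becomes (4-chlorophenyl)carbamoyl. Within the data shown here, no measured pair covers this change, so its size and direction are unknown from the data. Given that compound 2 gives only a limit, the step from compound 2 to compound 3 is expected to be an at least 1.1-fold lower number from compound 2 to compound 3 (0.04 log units; that floor lies within the scatter), that is no change beyond the scatter that can be told from here. Compound 3 is accordingly estimated at 180000 nM in this assay, with a range of 50000 nM to 600000 nM, and most likely again only a limit.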

Compound 3, half-maximal inhibitory concentration: > 200000 nM
Compound 3 ended at the assay's limit; the forecaster's own chance of this, stated with the estimate: 75%; middle value at least 1.1-fold (0.04 log units) from the limit.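

No step can be read from compound 2 to compound 3, since both end at a limit and neither gives a number: the limit of > 200000 nM in this assay, at which 2 of the 3 values shown sit.

Where either compound lies past that limit stays open, as does the size and direction of chloro in place of methoxy on an aromatic carbon.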